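Bromo to cyclopentenyl on the fused ring of compound 1

The source may report more compounds than this note shows. Statements on the series, on what has been measured and on what is new or still open speak of the compounds shown alone.

Measured compounds:
compound 1, `Cc1c(C(=O)Nc2ccc(Oc3ncnc4[nH]cc(-c5ccccc5)c34)c(F)c2)c(=O)c2cc(Br)ccc2n1C`: 3120 nM
compound 2, `CCc1ccc2c(c1)c(=O)c(C(=O)Nc1ccc(Oc3ncnc4[nH]cc(-c5ccccc5)c34)cc1F)c(C)n2C`: 30 nM

The read-out throughout is an assay on isolated protein for inhibition of tyrosine-protein kinase receptor UFO (Homo sapiens), read by FRET and Z'-LYTE, with a stated time of 1.5 h; a lower number here means a stronger inhibitor, a higher number a weaker inhibitor. Compound 1 stands at the highest of the two numbers recorded; its nearest neighbour, compound 2, sits a long way lower, a gap well beyond the scatter of repeated measurement. Nothing else on the table connects the two by a single change, so the gap says only where each stands, not what accounts for it.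

Compound 3, `Cc1c(C(=O)Nc2ccc(Oc3ncnc4[nH]cc(-c5ccccc5)c34)c(F)c2)c(=O)c2cc(C3=CCCC3)ccc2n1C`, is the next compound to be measured in this assay. It differs from compound 1 in one place: cyclopent-1-en-1-yl in place of bromo on an aromatic carbon. Going by the values given here, no measured pair shows the same exchange, so the size of the step has to be judged without a precedent. A move from bromo to cyclopent-1-en-1-yl at this position is a substantial change in the group attached to the core of compound 1, and a step of meaningful size in either direction is plausible; the expectation leans toward a modest gain, with a step of a 2.1-fold lower number from compound 1 to compound 3 (0.32 log units; beyond the scatter) expected. For compound 3 the estimate is 1500 nM, with a likely range from 300 nM to 6000 nM.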

Compound 3, half-maximal inhibitory concentration: 3320 nM
Beside the measured number, compound 3's estimate is 2.2-fold (0.35 log units) below it, within the range that was stated.
By their numbers in this assay, from the lowest: compound 2; then compounds 1 and 3 (each within the scatter of the next).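

In this assay, going by these compounds alone, the exchange of bromo for cyclopent-1-en-1-yl on this aromatic carbon gives a 1.1-fold higher number from compound 1 to compound 3 (0.03 log units; within the scatter) and is the first single-place step available. Compound 1 and compound 3 cannot be told apart in this read-out, so at this position, in this background, a group of 5 heavy atoms with a non-aromatic ring and a double bond reads the same as a single bromine atom. No independent measurement bears on why this exchange leaves the number within the scatter.

This single step does not show whether other groups on the same aromatic carbon, such as a primary amine, a carboxylic acid, a morpholine ring or a longer alkyl chain, would also read the same as bromo, or whether plain hydrogen would. As far as these compounds go, compound 2 differs from compound 1 and from compound 3 in more than one place, so this pair does not assign its separate standing to any one change, and whether the same exchange would read alike in that background remains open.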